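The source may hold more compounds than are shown below. What is called first, only, known or untested is meant among the compounds shown, and "the series" means these compounds.

Measured in a functional assay on DU-145 cells (Homo sapiens) for inhibition, read by trypan blue exclusion, with a stated time of 96 h; on this read-out lower numbers stand for stronger inhibition of growth and higher numbers for weaker inhibition of growth:
- Compound 1 `Cc1ccsc1/C=C(/SCc1ccc(Cl)cc1)C(=O)c1ccc(Cl)cc1`: 50000 nM
- Compound 2 `O=C(/C(=C\c1c(O)cc(O)cc1O)SCc1ccc(Cl)cc1)c1ccc(Cl)cc1`: > 100000 nM (a limit)
- Compound 3 `CN(C)c1ccc(/C=C(\C(=O)c2ccc(Cl)cc2)S(=O)(=O)c2ccc(Br)cc2)cc1`: > 100000 nM (a limit)

Compound 3 has no number, only the limit > 100000 nM. That limit is shared by most of the set: the limit of > 100000 nM in this assay, at which 2 of the 3 values shown sit.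

Compound 4 `CN(C)c1ccc(/C=C(/SCc2ccc(Cl)cc2)C(=O)c2ccc(Cl)cc2)cc1` carries (4-chlorobenzyl)sulfanyl in place of (4-bromophenyl)sulfonyl, on a double-bonded chain carbon bound to a carbonyl carbon and a double-bonded chain carbon: (4-chlorobenzyl)sulfanyl in place of (4-bromophenyl)sulfonyl on a double-bonded chain carbon bound to a carbonyl carbon and a double-bonded chain carbon.

For the measured compounds named here, no measured step covers this change. Going by the values given here, the one measured step, an at least 2.0-fold higher number from compound 1 to compound 2 (0.30 log units; that floor lies within the scatter), lies elsewhere and sets no size here. Compound 1, which carries the entering group, gives 50000 nM, so a modest move toward stronger inhibition is expected in this assay. The expected step is an at least 2.2-fold lower number from compound 3 to compound 4 (0.34 log units; beyond the scatter). For compound 4 the estimated value is 45000 nM, with an expected range of 8000 nM to 100000 nM.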

Compound 4, concentration for 50% growth inhibition: > 100000 nM
Compound 4 was reported as a limit; the forecaster's own chance of this, stated with the estimate: 35%; at least 2.2-fold (0.34 log units) between middle value and limit.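

With 4-(dimethylamino)phenyl kept on the chain, (4-chlorobenzyl)sulfanyl at this position leaves compound 4 reported only as a limit, just as compound 3 was with (4-bromophenyl)sulfonyl, so the steps that link compound 4 to compound 3 and compound 2 cannot be read. The only readable step is an at least 2.0-fold higher number from compound 1 to compound 4 (0.30 log units; that floor lies within the scatter), so the change from 3-methylthiophen-2-yl to 4-(dimethylamino)phenyl is not shown to exceed the scatter. In this assay compound 4 joins most of the set at a limit: the limit of > 100000 nM in this assay, at which 3 of the 4 values shown sit.

As far as these compounds go, how far compound 2, compound 3 and compound 4 lie past that limit stays open. So does whether a primary amine or a carboxylic acid on the benzyl ring of compound 4 would yield a measurable number.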